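The source may report more compounds than this note shows. Statements on the series, on what has been measured and on what is new or still open speak of the compounds shown alone.

Measured compounds: compound 1 `O=C(COc1ccc2cc(C(O)(C(F)(F)F)C(F)(F)F)c(O)cc2c1)Nc1nc2ccccc2s1`, compound 2 `COc1ccc(CNC(=O)COc2ccc3cc(C(O)(C(F)(F)F)C(F)(F)F)c(O)cc3c2)cc1OC` and compound 3 `O=C(COc1ccc2cc(C(O)(C(F)(F)F)C(F)(F)F)c(O)cc2c1)Nc1ccc(-c2ccccc2)cc1`.

In an assay on isolated protein for inhibition of receptor-type tyrosine-protein phosphatase C (Homo sapiens), read by spectrophotometry (a lower number here means a stronger inhibitor, a higher number a weaker inhibitor), compound 1 gives 10900 nM. Compound 3 gives 3400 nM in this assay. Compound 2 reaches only a limit of this assay, > 20000 nM, and reports no number (the limit of > 20000 nM in this assay, at which 1 of the 3 values shown sits). Among the two numbers, compound 1 stands highest; its nearest neighbour is compound 3, with a 3.2-fold lower number from compound 1 to compound 3 (0.51 log units; beyond the scatter). Toward compound 2 the step is an at least 1.8-fold higher number from compound 1 to compound 2 (0.26 log units; that floor lies within the scatter), and from compound 2 to compound 3 it reads an at least 5.8-fold lower number from compound 2 to compound 3 (0.76 log units; beyond the scatter).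

Compound 4 `O=C(COc1ccc2cc(C(O)(C(F)(F)F)C(F)(F)F)c(O)cc2c1)NC1CC1` differs from compound 1 by cyclopropyl in place of 1,3-benzothiazol-2-yl on an amide-type nitrogen. Within the data shown here, the measured steps show that a 4-phenylphenyl on the amide-type nitrogen lowers the number and a 3,4-dimethoxybenzyl raises it to the limit; no measured step replaces the 1,3-benzothiazol-2-yl with a group as small as cyclopropyl. Compound 4 is therefore expected to give a higher number in this assay, an estimated step of a 2.3-fold higher number from compound 1 to compound 4 (0.36 log units; beyond the scatter). For compound 4 the estimate is 25000 nM, expected between 8000 nM and 80000 nM.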

Compound 4, half-maximal inhibitory concentration: > 20000 nM
Compound 4 gave a limit, no number; the forecaster's own chance of this, stated with the estimate: 60%; the middle value does not contradict the limit.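

Cyclopropyl in place of 1,3-benzothiazol-2-yl on the amide-type nitrogen gives an at least 1.8-fold higher number from compound 1 to compound 4 (0.26 log units; that floor lies within the scatter), so the loss against compound 1 can be stated only as a floor. Against the 4-phenylphenyl of compound 3, the same small ring gives an at least 5.8-fold higher number from compound 3 to compound 4 (0.76 log units; beyond the scatter), a drop that clearly exceeds the scatter. With this second limit, only 1,3-benzothiazol-2-yl and 4-phenylphenyl, the two groups attached through an aromatic ring, give numbers in this assay, whereas cyclopropyl and 3,4-dimethoxybenzyl leave compound 4 and compound 2 at a limit: the limit of > 20000 nM in this assay, at which 2 of the 4 values shown sit.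

Compound 2 and compound 4 both stand at a limit, so the step between them cannot be read. On these data alone, it remains open whether a plain phenyl or a cyclohexyl on the amide-type nitrogen would return a number.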